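This account rests on a few compounds, and the source may have more. Where it says the series, first, only, none or still open, it means among the compounds named here.

Measured compounds in an assay on CHO cells for positive allosteric modulation of metabotropic glutamate receptor 5 (Rattus norvegicus), read by FLIPR; on this read-out lower numbers stand for an effect already at smaller amounts and higher numbers for an effect only at larger amounts of compound:
- compound 1 `O=C(Nc1ccc(Cl)cc1CN1C(=O)c2ccccc2C1=O)c1ncccn1`; compound 1 gives < 1000 nM, which is a limit of the assay and not a number.
- compound 2 `O=C(Nc1ccc(Cl)cc1CN1C(=O)c2ccccc2C1=O)C1CCCCC1`; compound 2 gives < 1000 nM, likewise a limit.
- compound 3 `O=C(Nc1ccc(Cl)cc1CN1C(=O)c2ccccc2C1=O)c1cncs1`; compound 3 gives < 1000 nM, again a limit.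

Compound 3 therefore stands at the limit of < 1000 nM in this assay, at which 3 of the 3 values shown sit, undistinguished from the other two. The steps a step that the two limits leave unreadable from compound 1 to compound 2, a step that the two limits leave unreadable from compound 1 to compound 3 and a step that the two limits leave unreadable from compound 2 to compound 3 give no size, so the carbonyl substituent has so far shown no readable effect in this assay .

Compound 4 `O=C(Nc1ccc(Cl)cc1CN1C(=O)c2ccccc2C1=O)c1cccnn1` differs from compound 3 by pyridazin-3-yl in place of 1,3-thiazol-5-yl on a carbonyl carbon. Going by the values given here, no measured step bears on this change with a readable size; the three limits suggest only that compound 4 is expected to sit at the same limit, so a step that the limit leaves unreadable from compound 3 to compound 4 is expected, not beyond the scatter. Compound 4 is estimated at 300 nM, within 30 nM to 1000 nM.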

Compound 4, half-maximal effective concentration: < 1000 nM
Compound 4 ended at the assay's limit; the forecaster's own chance of this, stated with the estimate: 85%; the middle value lies beyond the limit too.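

Compound 4 gives no readable step against compound 1, compound 2 or compound 3, as all four sit at one limit: the limit of < 1000 nM in this assay, at which 4 of the 4 values shown sit.

The compounds shown leave open whether the carbonyl substituent changes the value in this assay at all, and by how much.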